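Indole carbamates: phenyl for pyridinyl at the carbamate oxygen

The compounds below may be only part of what the source reports. "The series", "measured", "known", "first", "only" and "open" are said of these compounds alone.

compound 1 `O=C(NCCCCCCn1ccc2ccccc21)Oc1cccnc1`: 5.2 nM
compound 2 `CC(=O)c1c(-c2ccccc2)c(-c2ccccc2)n(CCCCCCNC(=O)Oc2ccccc2)c1C`: > 10000 nM

For the measured compounds named here, in an assay on microsomes from brain (strain Sprague-Dawley) for inhibition of Fatty-acid amide hydrolase 1 (Rattus norvegicus), read by fluorescence and HPLC, with stated times of 10 min and 60 min (on this read-out higher numbers stand for weaker inhibition and lower numbers for stronger inhibition), compound 1 gives 5.2 nM, the only numeric value in the set. Compound 2 reaches only a limit of the assay, > 10000 nM; (the limit of > 10000 nM in this assay, at which 1 of the 2 values shown sits). Compound 3 `O=C(NCCCCCCn1ccc2ccccc21)Oc1ccccc1` carries phenyl in place of pyridin-3-yl on an oxygen next to a carbonyl group. Going by the values given here, no step between measured compounds is available, and compound 2 differs from compound 1 in more than this one place, so its limit bears only loosely on the change. A step toward weaker inhibition, beyond the scatter, is expected: a 9.6-fold higher number from compound 1 to compound 3 (0.98 log units; beyond the scatter). Compound 3 is estimated at 50 nM, within the range 10 nM to 300 nM.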

Compound 3, half-maximal inhibitory concentration: 250 nM
Beside the measured number, compound 3's estimate is 5.0-fold (0.70 log units) below it; measured number inside the range.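

With the rest of compound 1 unchanged, the ring on the oxygen next to a carbonyl group proves a sensitive place: in this assay, phenyl in place of pyridin-3-yl gives a 48-fold higher number from compound 1 to compound 3 (1.68 log units; beyond the scatter), a large loss. Inhibition remains measurable with the carbon-only ring, so the ring nitrogen is not required for activity, though the stronger value goes with pyridin-3-yl. Nothing shown gives a cause for this step.

On these data alone, whether pyridin-2-yl or pyridin-4-yl would match pyridin-3-yl remains open. So does whether an amine or a carboxylic acid on the phenyl would restore inhibition.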